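Chloro on the pendant phenyl across two amide cores

The compounds below may be only part of what the source reports. "The series", "measured", "known", "first", "only" and "open" are said of these compounds alone.

Compound 1 `O=C(Nc1nnc(-c2ccccc2)s1)c1cc(Br)ccc1O` and compound 2 `O=C(Nc1nnc(-c2ccc(Cl)cc2)s1)c1cc(Br)ccc1O` share one core and differ only by chloro in place of hydrogen on an aromatic carbon. In a functional assay on B16-F10 cells (Mus musculus) for antiproliferative activity, read by MTT assay, with a stated time of 48 h (on this read-out higher numbers stand for weaker inhibition and lower numbers for stronger inhibition), compound 1 gives 1280 nM, and compound 2 gives 560 nM; the step between them is a 2.3-fold lower number from compound 1 to compound 2 (0.36 log units; beyond the scatter). Compound 3 `O=C(Nc1nnc(-c2ccccc2)s1)c1ccccc1` carries a second core; the difference between the two cores is not broken down here. In this assay compound 3 gives 5150 nM, the highest number among the three measured compounds. Compound 4 `O=C(Nc1nnc(-c2ccccc2)s1)c1ccc(Cl)cc1` is the unmeasured partner of compound 3 and differs from it by chloro in place of hydrogen on an aromatic carbon, the same change made in the same place as that from compound 1 to compound 2. For the measured compounds named here, the expectation for compound 4 rests on that single earlier pair, because a 2.3-fold lower number from compound 1 to compound 2 (0.36 log units; beyond the scatter) is the only guide for what the chloro adds; with one example the expectation is held loosely. For compound 4 the expected step is a 2.3-fold lower number from compound 3 to compound 4 (0.37 log units; beyond the scatter), close in size to the earlier one. Compound 4 is accordingly estimated at 2200 nM, within a range from 1000 nM to 5000 nM.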

Compound 4, half-maximal inhibitory concentration: 4650 nM
For compound 4 the middle estimate is 2.1-fold (0.33 log units) below the measured one; the measured number falls inside the stated range.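

In this assay, chloro in place of hydrogen on the core of compound 3 gives a 1.1-fold lower number from compound 3 to compound 4 (0.04 log units; within the scatter), so compound 3 and compound 4 cannot be told apart on this read-out. Set beside the step on the core of compound 1, this result does not establish a real difference between the two cores in how they respond to the change: the same change on two cores in this assay, a 2.3-fold lower number (0.36 log units; beyond the scatter) from compound 1 to compound 2 and a 1.1-fold lower number (0.04 log units; within the scatter) from compound 3 to compound 4, 2.1-fold (0.31 log units) apart, within the scatter of two such steps. The two pairs therefore neither show that the change carries over at the same size nor show that it fails to carry over, and one pair per core is too little to support a rule in either direction.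

Still open is how much of the gap between the two cores belongs to the bromo group and how much to the hydroxyl group, since the compounds shown do not separate them. Also open, going by these compounds, is whether a group other than chloro at the same place, such as methoxy or an amine, would give a clearer step on both cores.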